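Bromo on the phenoxy ring of compound 3

The compounds below may be only part of what the source reports. "The series", "measured", "known", "first", "only" and "open" are said of these compounds alone.

- In a functional assay on DU-145 cells (Homo sapiens) for cytotoxicity, read by MTT assay, with a stated time of 48 h (a higher number here means a weaker inhibitor, a lower number a stronger inhibitor), compound 1 `COc1ccc(/C=C/C(=O)/C=C/c2cc3ccccc3nc2Cl)cc1` gives > 10000 nM, a limit.
- In this assay compound 2 `COc1ccc(/C=C/C(=O)/C=C/c2cc3ccccc3nc2Oc2ccccc2)cc1OC` gives > 10000 nM, a limit.
- In this assay compound 3 `COc1cc(OC)c(/C=C/C(=O)/C=C/c2cc3ccccc3nc2Oc2ccccc2)c(OC)c1` gives > 10000 nM, a limit.

Compound 3 has no measured number in this assay, and its position is defined only by the limit of > 10000 nM in this assay, at which 3 of the 3 values shown sit. The three compounds therefore cannot be ranked against one another.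

The next compound is compound 4 `COc1cc(OC)c(/C=C/C(=O)/C=C/c2cc3ccccc3nc2Oc2ccc(Br)cc2)c(OC)c1`, which differs from compound 3 by bromo in place of hydrogen on an aromatic carbon. In words, this is bromo in place of hydrogen on an aromatic carbon, taking phenoxy to 4-bromophenoxy.

Among the compounds with values here, no measured pair differs in one place only, so the series gives no direct measure of what a single change does in this assay. With no such guide, a large step is not expected. If a number does appear, it can only be expected on the stronger side of the limit held by compound 3, and the most likely outcome is no change beyond the scatter. The expected change is a number no higher from compound 3 to compound 4 (the limit leaves the size open). For compound 4 the expected value is 10000 nM, with an estimated range from 3000 nM to 30000 nM.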

Compound 4, half-maximal inhibitory concentration: > 10000 nM
Compound 4 ended at the assay's limit; the forecaster's own chance of this, stated with the estimate: 65%; the middle value lies on the limit itself.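

No step can be read from compound 3 to compound 4, as both sit at the same limit: the limit of > 10000 nM in this assay, at which 4 of the 4 values shown sit.

The compounds shown leave open whether bromo in place of hydrogen on an aromatic carbon has any effect in this assay, and which change, if any, would bring a value inside the limit.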